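Notes on the step from compound 2 to compound 3

The source may hold more compounds than are shown below. What is called first, only, known or untested is meant among the compounds shown, and "the series" means these compounds.

In a functional assay on A549 cells (Homo sapiens) for cytotoxicity, read by MTT assay, with a stated time of 72 h (on this read-out higher numbers stand for weaker inhibition and lower numbers for stronger inhibition), compound 2 (`CCCCCCCCCCCCCCCCOP(=O)([O-])OCCC[N+](C)(C)C`) gives 41500 nM. In this assay, compound 1 (`CCCCCCCCCCCCCCCCOP(=O)([O-])OCCC[N+](C)(C)Cc1ccccc1`) gives 57600 nM. These two numbers are the only ones available and lie within the scatter of each other, so compound 2 stands level with compound 1.

Compound 3 (`CCCCCCCCCCCCCCCCOP(=O)([O-])OCCC[n+]1ccccc1`) has not yet been measured. Its structural difference from compound 2 is a group of 6 heavy atoms (5 carbon, 1 nitrogen; one six-membered aromatic ring with 1 hetero atom) in place of a group of 4 heavy atoms (3 carbon, 1 nitrogen; no ring), on a saturated chain carbon, three bonds along the chain from an oxygen. Both groups carry a net charge of +1.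

Within the data shown here, one measured step bears on this change: a 1.4-fold lower number from compound 1 to compound 2 (0.14 log units; within the scatter). That step also alters the group bearing the charge, replacing phenyl with hydrogen, and it stays within the scatter. Among the measured compounds shown here, it is only indirect evidence, as no measured compound contains the six-membered aromatic ring of compound 3. A larger shift in either direction therefore cannot be ruled out.

The estimated step is a 1.0-fold lower number from compound 2 to compound 3 (0.02 log units; within the scatter), and no change beyond the scatter is expected. For compound 3 the expected value is 40000 nM, with an estimated range of 18000 nM to 85000 nM.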

Compound 3, half-maximal inhibitory concentration: 61600 nM
Estimate against measurement, compound 3: 1.5-fold (0.19 log units) below; the range from low to high includes it.
By their numbers in this assay, from the lowest: compounds 2, 1 and 3 (each within the scatter of the next).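

In this assay the saturated chain carbon, three bonds along the chain from an oxygen, now carries a group with one six-membered aromatic ring with 1 hetero atom, and replacing the group of 4 heavy atoms with no ring gives a 1.5-fold higher number from compound 2 to compound 3 (0.17 log units; within the scatter) as the direct reading for this change. Set against the group of 10 heavy atoms with one six-membered aromatic ring of carbon only, the same place gives a 1.1-fold higher number from compound 1 to compound 3 (0.03 log units; within the scatter) as a second reading, so the new ring has now been compared with both earlier groups. The three groups, each with a net charge of +1, read level with one another at this place, and no separate measurement on these compounds speaks to the reason for this.

Going by these compounds, it remains open whether a saturated piperidinium ring or a primary amine would also read level with these three groups. On these data alone, whether the same level reading would hold on a core with a shorter chain also remains open.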